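From Nitro to Tert-Butoxy in a Narrow Series

The source may hold more compounds than are shown below. What is called first, only, known or untested is meant among the compounds shown, and "the series" means these compounds.

In a functional assay on HepG2 cells (Homo sapiens) for inhibition, read by MTT assay, with a stated time of 72 h (on this read-out lower numbers stand for stronger inhibition and higher numbers for weaker inhibition), compound 1 (`COc1ccc(-c2nnc(SCCCN3CCN(c4nc5ccccc5o4)CC3)o2)cc1`) gives 66100 nM, compound 2 (`O=[N+]([O-])c1ccc(-c2nnc(SCCCN3CCN(c4nc5ccccc5o4)CC3)o2)cc1`) gives 67200 nM and compound 3 (`Clc1ccc(-c2nnc(SCCCN3CCN(c4nc5ccccc5o4)CC3)o2)cc1`) gives 121000 nM. Compound 2 therefore lies within the scatter of both other compounds. Compound 4 (`CC(C)(C)Oc1ccc(-c2nnc(SCCCN3CCN(c4nc5ccccc5o4)CC3)o2)cc1`) has tert-butoxy in place of nitro on an aromatic carbon. Tert-butoxy itself has not been measured, but three swaps on that carbon bear on the change: a 1.0-fold higher number from compound 1 to compound 2 (0.01 log units; within the scatter), a 1.8-fold higher number from compound 1 to compound 3 (0.26 log units; within the scatter) and a 1.8-fold higher number from compound 2 to compound 3 (0.26 log units; within the scatter). Given these small steps, none beyond the scatter is expected in this assay, and the estimated step is a 1.2-fold higher number from compound 2 to compound 4 (0.08 log units; within the scatter). For compound 4, the expected value is 80000 nM, with an estimated range of 35000 nM to 170000 nM.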

Compound 4, half-maximal inhibitory concentration: 121000 nM
The estimate for compound 4 lay 1.5-fold (0.18 log units) below the measured number; the measured number falls inside the stated range.
By their numbers in this assay, from the lowest: compounds 1, 2, 3 and 4 (each within the scatter of the next).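

In this assay, tert-butoxy on this aromatic carbon adds a fourth group to the comparison, and the steps to it are a 1.8-fold higher number from compound 2 to compound 4 (0.26 log units; within the scatter) with nitro leaving, no change at the digits printed from compound 3 to compound 4 (within the scatter) with chloro leaving and a 1.8-fold higher number from compound 1 to compound 4 (0.26 log units; within the scatter) with tert-butyl in place of methyl on the oxygen. All three stay within the scatter, even though tert-butoxy has more heavy atoms than nitro, so this read-out does not separate the four groups. On these data alone, whether an amine or a carboxylic acid on this carbon would give a step beyond the scatter stays open. Nor does any measurement at hand explain why these steps are so small.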